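The compounds below may be only part of what the source reports. "The series", "measured", "known", "first", "only" and "open" are said of these compounds alone.

Measured compounds:
- compound 1, `C=CC(=O)Nc1cccc(Cn2nc(-c3ccc(Oc4ccccc4)cc3)cc2C(=O)OCC)c1`: in a functional assay on Z-138 cells (Homo sapiens) for inhibition, read by luminescence and CellTiter-Glo, with a stated time of 72 h (a lower number here means a stronger inhibitor, a higher number a weaker inhibitor), compound 1 gives 7800 nM
- compound 2, `C=CC(=O)N1CCCC(n2nc(-c3ccc(Oc4ccccc4)cc3)cc2C(=O)OCC)C1`: compound 2 gives 44000 nM
- compound 3, `C=CC(=O)Nc1cccc(Cn2nc(-c3ccc(Oc4ccccc4)cc3)cc2CO)c1`: compound 3 gives 6000 nM

Compound 1 stands second highest of the three numbers. Its nearest neighbour is compound 3, reached by a 1.3-fold lower number from compound 1 to compound 3 (0.11 log units; within the scatter), a change that sits on a different part of the shared core and does not separate the two compounds. Compound 2 lies furthest away, and its value next to that of compound 1 shows a clearly weaker inhibitor.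

Compound 4, `CCOC(=O)c1cc(-c2ccc(Oc3ccccc3)cc2)nn1Cc1ccc(NC(=O)CCl)cc1`, has not yet been measured. It differs from compound 1 in one place: 4-(((chloromethyl)carbonyl)amino)phenyl in place of 3-((vinylcarbonyl)amino)phenyl on a saturated chain carbon bound to an aromatic nitrogen. The change both swaps the group carrying the reactive double bond for one carrying a chlorine and moves the attachment point on the phenyl ring.

Within the data shown here, none of the measured steps bears on this change. Among the measured compounds shown here, the only single-place step available, from compound 1 to compound 3, concerns the ester and stays within the scatter, so nothing here tells how the exchanged amide group affects this assay. With no guide, no step beyond the scatter is expected, and the estimate stays close to compound 1 with a wide range. Compound 4 is expected to give about 10000 nM, between 3000 nM and 40000 nM, which would mean a step of a 1.3-fold higher number from compound 1 to compound 4 (0.11 log units; within the scatter).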

Compound 4, half-maximal inhibitory concentration: 400 nM
Beside the measured number, compound 4's estimate is 25-fold (1.40 log units) above it, and the stated range ends above it.
By their numbers in this assay, from the lowest: compound 4; then compounds 3 and 1 (each within the scatter of the next); then compound 2.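

In this assay the group on the saturated chain carbon bound to an aromatic nitrogen proves to have a large bearing on the number, with a 20-fold lower number from compound 1 to compound 4 (1.29 log units; beyond the scatter) as the step. Among these compounds, the only earlier single-place step, a 1.3-fold lower number from compound 1 to compound 3 (0.11 log units; within the scatter), concerned a different part of the shared core and gave no sign of this. The new step combines two differences, since 4-(((chloromethyl)carbonyl)amino)phenyl differs from 3-((vinylcarbonyl)amino)phenyl both in the group on the amide carbonyl and in the number marking its place on the phenyl ring, and no measurement shown here gives a reason for the size of the step.

The compounds shown leave open which of the two differences carries the step, a question that 3-(((chloromethyl)carbonyl)amino)phenyl or 4-((vinylcarbonyl)amino)phenyl on the same core could separate. Also open, as far as these compounds go, is whether the chlorine itself matters, which a plain acetyl on the amide nitrogen, with a methyl in place of the chloromethyl, could test in the setting of compound 4.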